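The source may report more compounds than this note shows. Statements on the series, on what has been measured and on what is new or still open speak of the compounds shown alone.

Measured so far:
compound 1 `CC/C=C\CC1C(=O)C=CC1CC(=O)OC` — 19000 nM
compound 2 `CC/C=C\C[C@H]1C(=O)C=C[C@H]1CC(=O)OCC` — 20000 nM
compound 3 `CC/C=C\C[C@H]1C(=O)C=C[C@H]1CC(=O)OCCCC` — 23000 nM

The three measured compounds share one core and differ only in the group on the oxygen next to the carbonyl. In a functional assay on RAW264.7 cells (Mus musculus) for inhibition, read by ELISA, with a stated time of 24 h (on this read-out higher numbers stand for an effect only at larger amounts of compound and lower numbers for an effect already at smaller amounts), compound 3 gives 23000 nM; this is the highest of the three numbers, but compound 2 and compound 1 both lie within the scatter of it, so no order among the three can be read from the data. Going by the values given here, the one single-point step that has been measured, a 1.2-fold higher number from compound 2 to compound 3 (0.06 log units; within the scatter), was itself within the scatter, and the values of compound 1 and compound 2 show the same picture for methyl against ethyl on that oxygen.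

Compound 4 `CC/C=C\C[C@H]1C(=O)C=C[C@H]1CC(=O)Oc1ccc(O)cc1` carries the change (4-hydroxyphenyl in place of butyl on an oxygen next to a carbonyl group). Among the compounds with values here, the step from compound 3 to compound 4 is larger in kind than any step measured here: an aromatic ring with a hydrogen-bond donor and acceptor enters where only saturated chains have been varied, so the measured steps give no direct precedent for its size or direction. On the evidence that chain length at this position left the read-out unchanged, no step beyond the scatter is expected, with a wide range to allow for the new group. Compound 4 is therefore expected to give about 20000 nM (range 7000 nM to 60000 nM), corresponding to an expected step of a 1.2-fold lower number from compound 3 to compound 4 (0.06 log units; within the scatter).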

Compound 4, half-maximal effective concentration: 23000 nM
For compound 4 the middle estimate is 1.2-fold (0.06 log units) below the measured one, within the range that was stated.
By their numbers in this assay, from the lowest: compounds 1, 2, 3 and 4 (each within the scatter of the next).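

In this assay, 4-hydroxyphenyl in place of butyl on an oxygen next to a carbonyl group gives no change at the digits printed from compound 3 to compound 4 (within the scatter) and 4-hydroxyphenyl in place of ethyl at the same place gives a 1.2-fold higher number from compound 2 to compound 4 (0.06 log units; within the scatter) in the read-out. Until now this position had been varied only through saturated chains, whereas these two steps bring in a six-membered aromatic ring of carbon only, with a hydrogen-bond donor and a hydrogen-bond acceptor, and both steps still lie within the scatter, so among compounds 1 to 4 the read-out does not separate chains from this ring. No data are at hand that would account for this result.

Still open, as far as these compounds go, is whether any group on this oxygen gives a step beyond the scatter, for example a longer chain, a benzyl group, a plain phenyl without the hydroxyl, or a phenyl carrying an amine or a carboxylic acid. Also open, from the compounds shown here alone, is whether a change elsewhere on the shared core, rather than on this oxygen, would shift the number, as all four compounds keep that core and its side chain unchanged apart from the stereochemistry left unspecified in compound 1.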